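This account rests on a few compounds, and the source may have more. Where it says the series, first, only, none or still open, it means among the compounds named here.

Compound 1 `Cn1cc(C(=O)Nc2ccc(-c3ccccn3)c(C(F)(F)F)c2)c(=O)c2ccccc21` was measured in an ADME assay on LLC-PK1 cells (Sus scrofa) for permeability (on this read-out higher numbers stand for higher permeability and lower numbers for lower permeability), and gave 11 10^-6 cm/s. Compound 2 `Cn1cc(C(=O)Nc2ccc(-c3ccccn3)c(C(F)(F)F)c2)c(=O)c2cnccc21` gave 16 10^-6 cm/s in this assay, a number that sits close to compound 1, within the usual scatter. Compound 3 `COc1ccncc1C(=O)NC(=O)Nc1ccc(-c2ccccc2)c(C(F)(F)F)c1` gave 2.3 10^-6 cm/s, which lies clearly beneath compound 1. So compound 1 stands near the top of these three numbers, separated from compound 3 but not from compound 2. Compound 4 `Cn1cc(C(=O)Nc2ccc(-c3ccncc3)c(C(F)(F)F)c2)c(=O)c2ccccc21` differs from compound 1 in one place: pyridin-4-yl in place of pyridin-2-yl on an aromatic carbon. Among the compounds with values here, no measured pair shows this change, so the expectation rests on compound 1 alone; a modest downward step is expected, a 1.4-fold lower number from compound 1 to compound 4 (0.14 log units; within the scatter), though the result may well fall within the scatter. For compound 4 the expected value in this assay is 8 10^-6 cm/s, in a range from 4 10^-6 cm/s to 16 10^-6 cm/s.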

Compound 4, apparent permeability in the LLC-PK1 assay: 15 10^-6 cm/s
Compound 4: the middle estimate sits 1.9-fold (0.27 log units) below what was measured, within the range that was stated.
By their numbers in the LLC-PK1 assay, from the lowest: compound 3; then compounds 1, 4 and 2 (each within the scatter of the next).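

In the LLC-PK1 assay, pyridin-4-yl in place of pyridin-2-yl gives a 1.4-fold higher number from compound 1 to compound 4 (0.13 log units; within the scatter), so at this place, para to a large group, the nitrogen can change position with no clear effect on the read-out. In a physicochemical assay for solubility, at pH 7.4 (a higher number here means a more soluble compound, a lower number a less soluble compound), compound 1 gives 12 ug/mL and compound 4 gives 6.4 ug/mL, two numbers that also lie within the scatter of each other. Nothing available here explains either result. Still open, going by these compounds, is whether pyridin-3-yl, or a carboxylic acid on this ring, would keep both numbers in the same range. Also open, on these data alone, is whether the same swap would behave alike on the core of compound 2.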